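This account rests on a few compounds, and the source may have more. Where it says the series, first, only, none or still open, it means among the compounds named here.

Compound 2 `[SeH]c1nc(NCc2ccccc2)c2ccccc2n1` and compound 1 `CCCCC[Se]c1nc(NCc2ccccc2)c2ccccc2n1` share a core and differ in one place, (pentyl in place of hydrogen on a selenium). In a functional assay on HT-29 cells (Homo sapiens) for cytotoxicity, read by MTT assay, with a stated time of 72 h (a lower number here means a stronger inhibitor of growth, a higher number a weaker inhibitor of growth), compound 2 gives only a limit of the assay, > 100000 nM. Compound 1 likewise gives only a limit, > 100000 nM. The step from one to the other is therefore a step that the two limits leave unreadable from compound 2 to compound 1, because of the limit of > 100000 nM in this assay, at which 2 of the 3 values shown sit.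

Compound 3 `Nc1nc([SeH])nc2ncccc12` has a different core; the difference between the two cores is not broken down here. In this assay, among the compounds with values here, compound 3 gives 89600 nM, the only number among the three.

Compound 4 `CCCCC[Se]c1nc(N)c2cccnc2n1` stands to compound 3 as compound 1 stands to compound 2: the change is pentyl in place of hydrogen on a selenium, the same change on the same kind of place. Since the earlier step could not be read, the size of the new one rests only on compound 3 sitting close to where the two limits lie. The step from compound 3 to compound 4 is expected to be a 1.1-fold higher number from compound 3 to compound 4 (0.05 log units; within the scatter). In this assay compound 4 is therefore expected to give about 100000 nM, estimated between 40000 nM and 300000 nM.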

Compound 4, concentration for total growth inhibition: 20000 nM
Beside the measured number, compound 4's estimate is 5.0-fold (0.70 log units) above it; the whole stated range lies above it.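

In this assay, pentyl in place of hydrogen on a selenium gives a 4.5-fold lower number from compound 3 to compound 4 (0.65 log units; beyond the scatter) and so, on this core, the change goes with stronger growth inhibition, though the step is modest. The same change on the core of compound 1 cannot be sized, because compound 2 and compound 1 both give a limit rather than a number: the limit of > 100000 nM in this assay, at which 2 of the 4 values shown sit. This leaves one readable step on one core, which does not show that the change carries from one core to another, and compound 1 and compound 2 neither support nor contradict such a transfer.

From the compounds shown here alone, whether a shorter chain such as methyl, a longer chain such as octyl, or an amine at the end of the pentyl chain would lower the number further on the core of compound 3 stays open. Also open, going by these compounds, is the size of the change on the core of compound 1, which would need a number in place of a limit on both sides.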